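This account rests on a few compounds, and the source may have more. Where it says the series, first, only, none or still open, it means among the compounds named here.

Compound 3 `CCCOc1cc(C)c(-c2cccc(COc3ccc(S(=O)(=O)CC(=O)O)cc3)c2)c(C)c1` gives 69.2 nM in a functional assay on CHO cells for agonist activity at Free fatty acid receptor 1 (Homo sapiens), read by FLIPR and calcium flux (a higher number here means that more compound is needed for the effect, a lower number that less compound is needed), which is the highest of the three numbers recorded so far, although every gap to the other two lies within the scatter. Compound 1 `Cc1cccc(C)c1-c1cccc(COc2ccc(S(=O)(=O)CC(=O)O)cc2)c1` gives 66.1 nM in this assay, and compound 2 `CCOc1cc(C)c(-c2cccc(COc3ccc(S(=O)(=O)CC(=O)O)cc3)c2)c(C)c1` gives 63.1 nM. These three differ only in what sits on the aromatic carbon of the outer ring: a 1.0-fold lower number from compound 1 to compound 2 (0.02 log units; within the scatter), a 1.0-fold higher number from compound 1 to compound 3 (0.02 log units; within the scatter) and a 1.1-fold higher number from compound 2 to compound 3 (0.04 log units; within the scatter). None of these moved the number beyond the scatter.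

Compound 4 `Cc1cc(OCC(C)C)cc(C)c1-c1cccc(COc2ccc(S(=O)(=O)CC(=O)O)cc2)c1` carries the change (methyl in place of hydrogen on a saturated chain carbon bound to two saturated chain carbons), that is methyl in place of hydrogen on a saturated chain carbon bound to two saturated chain carbons, so that propoxy becomes isobutoxy. Going by the values given here, the steps that bear on it are the three just given, each of which grew or branched the same chain, and each of which stayed within the scatter. Among the compounds with values here, nothing among the measured compounds points to one further carbon on this chain behaving otherwise. The expected step is therefore a 1.0-fold higher number from compound 3 to compound 4 (0.00 log units; within the scatter), which is nothing beyond the scatter. Compound 4 is estimated to give about 70 nM in this assay, with a range from 35 nM to 140 nM.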

Compound 4, half-maximal effective concentration: 95.5 nM
Estimate against measurement, compound 4: 1.4-fold (0.13 log units) below, within the range that was stated.
By their numbers in this assay, from the lowest: compounds 2, 1, 3 and 4 (each within the scatter of the next).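

Branching the chain so that propoxy becomes isobutoxy still leaves the number in this assay within the scatter (a 1.4-fold higher number from compound 3 to compound 4 (0.14 log units; within the scatter)). The same holds when the isobutoxy compound is set against the shorter chain and against the bare aromatic carbon (a 1.5-fold higher number from compound 2 to compound 4 (0.18 log units; within the scatter); a 1.4-fold higher number from compound 1 to compound 4 (0.16 log units; within the scatter)), so among the four compounds shown, this place has taken hydrogen, ethoxy, propoxy and isobutoxy with no step beyond the scatter, and none of the compounds goes against that. No other measurement accompanies these numbers, and nothing available bears on this result.

The compounds shown leave open whether a longer chain such as hexyloxy, a ring-bearing group such as benzyloxy, or a chain ending in an amine or a carboxylic acid would carry the number beyond the scatter at this place. They also leave open whether the same holds when a sulfur atom or an amine nitrogen takes the place of the oxygen that joins the chain to the aromatic ring.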